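This account rests on a few compounds, and the source may have more. Where it says the series, first, only, none or still open, it means among the compounds named here.

Of the compounds shown here, three have so far been measured in a functional assay on PANC-1 cells (Homo sapiens) for inhibition, read by MTT assay, with a stated time of 24 h, tested at 10 uM; a lower number here means less inhibition, a higher number more inhibition at the concentration tested (going by the name of the read-out). Compound 1 `CC(C)=CCC/C(C)=C/CC1Cc2c(O)cc(=O)n(CCCO)c2CC1(C)C` gives 28.7% there, compound 2 `CC(C)=CCOc1cc(=O)n(CCCO)c2c1CC(CC=C(C)C)C(C)(C)C2` gives 20.7%, and compound 3 `CC(C)=CCC1Cc2c(OCCCNS(=O)(=O)c3ccc(Br)cc3)cc(=O)n(CCCO)c2CC1(C)C` gives 19.5%. Compound 2 lies within the usual scatter of both other compounds, so the three numbers do not set it apart. Compound 4 `CC(C)=CCC1Cc2c(OCCCNC(=O)c3cccs3)cc(=O)n(CCCO)c2CC1(C)C` has not yet been measured. It differs from compound 2 in one place: 2-(((thiophen-2-yl)carbonyl)amino)ethyl in place of 2-methylprop-1-en-1-yl on a saturated chain carbon bound to an oxygen on an aromatic ring. Compound 3 also carries a large replacement for the prenyl ether at this place, and its reading of 19.5% is indistinguishable from that of compound 2. Compound 4 is therefore expected to show no step beyond the scatter, a number 0.3 percentage points higher from compound 2 to compound 4 (within the scatter). Compound 4 is estimated at 21%, in a range from 9% to 33%.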

Compound 4, a percentage reported as inhibition, at one concentration (the size of the read-out at that concentration, not a potency): 33.6%
The estimate for compound 4 lay 12.6 percentage points below the measured number, outside the stated range (above it).
By their numbers in this assay, from the lowest: compounds 3, 2, 1 and 4 (each within the scatter of the next, the first and the last beyond it).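

In this assay, the place on a saturated chain carbon bound to an oxygen on an aromatic ring proves able to shift the reading: 2-(((thiophen-2-yl)carbonyl)amino)ethyl in place of 2-methylprop-1-en-1-yl gives a number 12.9 percentage points higher from compound 2 to compound 4 (beyond the scatter). The group on the amine nitrogen also matters, as (thiophen-2-yl)carbonyl in place of (4-bromophenyl)sulfonyl gives a number 14.1 percentage points higher from compound 3 to compound 4 (beyond the scatter), so size at this place alone does not set the number. Nothing available explains either step. On these data alone, whether the thiophene ring itself counts remains open, as a phenyl or furan ring on the same carbonyl could show, and so does the effect of a shorter chain.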